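Putting a 4-methoxybenzyl group on the sulfur

A few compounds are considered here, and "the series" means these few. Any claim that something is new, unique, unknown or untested is made for them only; others in the source may bear on it.

Compound 1 (`CCOC(=O)CSc1nnc(-c2cc(OC)c(OC)c(OC)c2)n1-c1ccc(OC)cc1`) gives > 60000 nM (a limit)
Compound 2 (`COc1cc(-c2nnc(S)n2-c2ccc(N(C)C)cc2)cc(OC)c1OC`) gives > 60000 nM (a limit)

Both readings come from a functional assay on HT-29 cells (Homo sapiens) for inhibition, read by MTT assay, with a stated time of 48 h (on this read-out lower numbers stand for stronger inhibition and higher numbers for weaker inhibition), and neither is a true number. Compound 2 stands on that limit, and so does compound 1 (the limit of > 60000 nM in this assay, at which 2 of the 2 values shown sit).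

Compound 3 (`COc1ccc(CSc2nnc(-c3cc(OC)c(OC)c(OC)c3)n2-c2ccc(N(C)C)cc2)cc1`) keeps the core of compound 2 and makes one change (4-methoxybenzyl in place of hydrogen on a sulfur): 4-methoxybenzyl in place of hydrogen on a sulfur. Within the data shown here, no measured pair of compounds shows what this change does, so any forecast here is loose. The estimated change is an at least 20-fold lower number from compound 2 to compound 3 (1.30 log units; beyond the scatter) and it points toward stronger inhibition, though there is a real chance that the new reading is a limit again. For compound 3 the estimated value is 3000 nM, with an expected range from 50 nM to 60000 nM in this test.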

Compound 3, half-maximal inhibitory concentration: > 60000 nM
Compound 3: only a limit was reported; the forecaster's own chance of this, stated with the estimate: 30%; middle value at least 20-fold (1.30 log units) from the limit.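

Compound 2 and compound 3 both give only a limit, not a number, in this assay, so no step between them can be read: the limit of > 60000 nM in this assay, at which 3 of the 3 values shown sit.

The compounds shown leave open whether 4-methoxybenzyl in place of hydrogen on the sulfur changes inhibition at all.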